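Dropping the terminal phosphorus group from compound 3

A few compounds are considered here, and "the series" means these few. Any claim that something is new, unique, unknown or untested is made for them only; others in the source may bear on it.

Measured compounds:
compound 1 `O=c1ccn([C@@H]2O[C@H](COP(=O)(O)O)[C@@H](O)[C@H]2O)c(SCCc2ccccc2)n1` > 100000 nM
compound 2 `CSc1nc(=O)ccn1[C@@H]1O[C@H](COP(=O)(O)O)[C@@H](O)[C@H]1O` > 100000 nM
compound 3 `COc1nc(=O)ccn1[C@@H]1O[C@H](COP(=O)(O)OP(=O)(O)O)[C@@H](O)[C@H]1O` 1370 nM

In an in vitro functional assay on 1321-N1 cells for agonist activity at P2Y purinoceptor 6 (Homo sapiens), read by scintillation proximity assay and inositol phosphate accumulation (on this read-out higher numbers stand for an effect only at larger amounts of compound and lower numbers for an effect already at smaller amounts), compound 1 gives only a limit, > 100000 nM. Compound 2 likewise gives only a limit in this assay, > 100000 nM. The step that the two limits leave unreadable from compound 1 to compound 2 is therefore unreadable. For the measured compounds named here, compound 3, with 1370 nM, is the only compound with a real number in this assay; the other two sit at the limit of > 100000 nM in this assay, at which 2 of the 3 values shown sit.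

Compound 4 `COc1nc(=O)ccn1[C@@H]1O[C@H](COP(=O)(O)O)[C@@H](O)[C@H]1O` differs from compound 3 by a hydrogen atom in place of a group of 4 heavy atoms (3 oxygen, 1 phosphorus; no ring), on an oxygen. Going by the values given here, no measured step follows this exact change, so the expectation rests on the values themselves: compound 3, carrying that group, gives a number, whereas compound 1 and compound 2, which like compound 4 lack it, give only the limit. Compound 4 is therefore expected to lose activity strongly, with a step of a 73-fold higher number from compound 3 to compound 4 (1.86 log units; beyond the scatter) estimated in this assay. The estimate for compound 4 is 100000 nM, between 20000 nM and 300000 nM, and most probably the assay will report only a limit.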

Compound 4, half-maximal effective concentration: 9800 nM
Beside the measured number, compound 4's estimate is 10-fold (1.01 log units) above it, outside the stated range (below it).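

Removing the terminal phosphorus group costs only a modest amount of activity in this assay, with a 7.2-fold higher number from compound 3 to compound 4 (0.85 log units; beyond the scatter), so this group is not needed for a measurable effect on this read-out. With that group gone, the substituent on the aromatic carbon separates the compounds: methoxy in place of methylsulfanyl gives an at least 10-fold lower number from compound 2 to compound 4 (1.00 log units; beyond the scatter), and methoxy in place of phenethylsulfanyl gives an at least 10-fold lower number from compound 1 to compound 4 (1.00 log units; beyond the scatter). Both of these steps start from a limit rather than a number: the limit of > 100000 nM in this assay, at which 2 of the 4 values shown sit.

The compounds shown leave open whether methylsulfanyl in place of methoxy would cost as much in compound 3, which keeps the terminal phosphorus group. They also leave open how other groups on that aromatic carbon, such as an amine or an ethoxy group, would compare with methoxy.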